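Acetamido analogue of compound 1 in the hexokinase series

A few compounds are considered here, and "the series" means these few. Any claim that something is new, unique, unknown or untested is made for them only; others in the source may bear on it.

Compound 1 `O=C(CI)NCCCCCCCCNc1ncnc2c1ncn2[C@@H]1O[C@H](COP(=O)(O)OP(=O)(O)OP(=O)(O)O)[C@@H](O)[C@H]1O` gives the highest of the three numbers in an assay on isolated protein for inhibition of hexokinase-3 (Rattus norvegicus), with a stated time of 6 h, tested at 10 mM (a lower number here means less inhibition, a higher number more inhibition at the concentration tested (going by the name of the read-out)), at 47%. Compound 2 `CN(CCCN(C)C(=O)CCCNc1ncnc2c1ncn2[C@@H]1O[C@H](COP(=O)(O)OP(=O)(O)OP(=O)(O)O)[C@@H](O)[C@H]1O)C(=O)CCCNC(=O)CI` gives 0% and compound 3 `CN(CCCCN(C)c1ncnc2c1ncn2[C@@H]1O[C@H](COP(=O)(O)OP(=O)(O)OP(=O)(O)O)[C@@H](O)[C@H]1O)C(=O)CCCCCNC(=O)CI` gives 0%, each lying beyond the scatter below compound 1. No pair among these three differs in a single place, so no measured step is available to scale the change. Compound 4 `CC(=O)NCCCCCCCCNc1ncnc2c1ncn2[C@@H]1O[C@H](COP(=O)(O)OP(=O)(O)OP(=O)(O)O)[C@@H](O)[C@H]1O` differs from compound 1 by hydrogen in place of iodo on a saturated chain carbon bound to a carbonyl carbon. Within the data shown here, without a comparable step, the expected step of a number 35 percentage points lower from compound 1 to compound 4 (beyond the scatter) is a loss of inhibition beyond the scatter, since compound 1 is the only member with a non-zero reading at 47%. Compound 4 is estimated at 12%, within 0% to 38%.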

Compound 4, a percentage reported as inhibition, at one concentration (the size of the read-out at that concentration, not a potency): 0%
Compound 4: middle estimate off by 12 percentage points, on the high side, and the stated range covers the measured number.
By their numbers in this assay, from the lowest: compounds 2, 3 and 4 (each within the scatter of the next); then compound 1.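

Hydrogen in place of iodo on a saturated chain carbon bound to a carbonyl carbon gives a number 47 percentage points lower from compound 1 to compound 4 (beyond the scatter) in this assay, the first single-place step in the series. Within this pair, the inhibition reading goes with the iodo: the acetamido compound 4 stands at 0% with the rest of the structure unchanged. No measurement shown here explains this step.

From the compounds shown here alone, whether bromo or chloro at this place would retain any of the reading of compound 1 remains open.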